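Methyl to Fluoro on the Shared Core

The source may report more compounds than this note shows. Statements on the series, on what has been measured and on what is new or still open speak of the compounds shown alone.

Of the compounds shown here, two built on one shared core have been tested in a functional assay on OVCAR-3 cells (Homo sapiens) for antiproliferative activity, read by MTT assay, with a stated time of 24 h; a higher number here means a weaker inhibitor, a lower number a stronger inhibitor. Compound 1 `O=c1[nH]cc(S(=O)(=O)Nc2cccc(-c3cn(-c4ccccc4)nn3)c2)c(=O)[nH]1` carries hydrogen at the position under study. In this assay compound 1 reaches only > 20000 nM, which is a limit of the assay rather than a number. For the measured compounds named here, compound 2 `Cc1ccc(-n2cc(-c3cccc(NS(=O)(=O)c4c[nH]c(=O)[nH]c4=O)c3)nn2)cc1` carries methyl at that same position, and in this assay compound 2 gives 3540 nM, the only number so far. Going by the values given here, the step of an at least 5.6-fold lower number from compound 1 to compound 2 (0.75 log units; beyond the scatter) is the single measured comparison, and it rests on one value sitting at the limit of > 20000 nM in this assay, at which 1 of the 2 values shown sits.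

Compound 3 `O=c1[nH]cc(S(=O)(=O)Nc2cccc(-c3cn(-c4ccc(F)cc4)nn3)c2)c(=O)[nH]1` is the next variant: fluoro in place of methyl on an aromatic carbon. Among the compounds with values here, the measured step from hydrogen to methyl, an at least 5.6-fold lower number from compound 1 to compound 2 (0.75 log units; beyond the scatter), shows that this position can move the readout, but no measured step compares methyl with fluoro directly. Compound 3 is expected to give 7000 nM, within a range from 2500 nM to 20000 nM. The expected step of a 2.0-fold higher number from compound 2 to compound 3 (0.30 log units; within the scatter) would be a modest weakening that may not exceed the scatter.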

Compound 3, half-maximal inhibitory concentration: > 20000 nM
Compound 3 was reported as a limit; the forecaster's own chance of this, stated with the estimate: 25%; at least 2.8-fold (0.45 log units) between middle value and limit.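

Replacing methyl with fluoro on this aromatic ring gives an at least 5.6-fold higher number from compound 2 to compound 3 (0.75 log units; beyond the scatter). In this assay the two compounds differ by a single heavy atom at this position, and only compound 2 gives a measurable number. Compound 3 gives > 20000 nM, which is a limit of the assay and not a number. Of the three groups shown, only methyl gives a measured number, and the step between the other two cannot be read, so hydrogen and fluoro cannot be ranked against each other: the limit of > 20000 nM in this assay, at which 2 of the 3 values shown sit.

Going by these compounds, it remains open how an ethyl or a methoxy group at this position would compare with methyl. On these data alone, it is also open whether an amine here would give a measurable number in this assay, or whether methyl would have the same effect elsewhere on this ring.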